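The compounds below may be only part of what the source reports. "The series", "measured", "known", "first", "only" and "open" are said of these compounds alone.

Compound 2 `COc1cc(C(=O)NS(=O)(=O)c2ccccc2C)ccc1Cc1cn(C(=O)N2CCOCC2)c2ccc(NC(=O)OC3CCCC3)cc12` gives the lower of the two numbers measured in an assay on isolated protein for binding affinity to cysteinyl leukotriene receptor 1 (Cavia porcellus); a lower number here means a stronger inhibitor, a higher number a weaker inhibitor: compound 2 gives 0.4 nM, while compound 1 `COc1cc(C(=O)NS(=O)(=O)c2ccccc2C)ccc1Cc1cn(C=O)c2ccc(NC(=O)OC3CCCC3)cc12` gives 1 nM, a gap shown by the step of a 2.5-fold lower number from compound 1 to compound 2 (0.40 log units; beyond the scatter). Compound 3 `COc1cc(C(=O)NS(=O)(=O)c2ccccc2C)ccc1Cc1cn(C(=O)NCCN(C)C)c2ccc(NC(=O)OC3CCCC3)cc12` differs from compound 2 by (2-(dimethylamino)ethyl)amino in place of morpholin-4-yl on a carbonyl carbon. Among the compounds with values here, only the step of a 2.5-fold lower number from compound 1 to compound 2 (0.40 log units; beyond the scatter) touches the same carbonyl carbon, and it exchanged a hydrogen for a ring rather than one ring for a chain, so it offers little guidance. For compound 3 the expected step of a 1.3-fold higher number from compound 2 to compound 3 (0.10 log units; within the scatter) is none beyond the scatter. Compound 3 is therefore estimated at 0.5 nM, with a range from 0.2 nM to 1.5 nM.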

Compound 3, half-maximal inhibitory concentration: 0.5 nM
For compound 3 middle estimate and measured number coincide at the digits printed; the range from low to high includes it.
By their numbers in this assay, from the lowest: compounds 2, 3 and 1 (each within the scatter of the next, the first and the last beyond it).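

In this assay, the open chain (2-(dimethylamino)ethyl)amino replaces the morpholin-4-yl ring on this carbonyl carbon with a 1.3-fold higher number from compound 2 to compound 3 (0.10 log units; within the scatter), so at this position a ring is not needed to stay within the scatter of compound 2. The step of a 2.0-fold lower number from compound 1 to compound 3 (0.30 log units; within the scatter) also lies within the scatter, so compound 3, unlike compound 2, cannot be told apart from compound 1, which has hydrogen here. No measured evidence bears on this result. Still open, as far as these compounds go, is how a carboxylic acid or a longer chain on this carbonyl carbon would fare.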